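This account rests on a few compounds, and the source may have more. Where it says the series, first, only, none or still open, it means among the compounds named here.

Compound 1 `Cc1ccccc1-n1nc(-c2ccccc2)nc1CNc1ccc(C(=O)NO)cc1` gives 57.1% in an assay on Sf9 cells for inhibition of protein deacetylase HDAC6 (Homo sapiens), read by fluorescence, with a stated time of 40 min, tested at 100 nM; a lower number here means less inhibition, a higher number more inhibition at the concentration tested (going by the name of the read-out). Compound 2 `COc1ccc(-n2nc(-c3ccccc3)nc2CNc2ccc(C(=O)NO)cc2)cc1` gives 63.4%. Compound 3 `COc1ccc(-c2nc(CNc3ccc(C(=O)NO)cc3)n(-c3ccccc3)n2)cc1` gives 77.6%.

Compound 3 stands highest of the three numbers, with compound 2 nearest and compound 1 furthest, and both gaps lie beyond the usual scatter. Compound 4 `Cc1ccc(-c2nc(CNc3ccc(C(=O)NO)cc3)n(-c3ccccc3)n2)s1` is not yet measured. It differs from compound 3 in one place: 5-methylthiophen-2-yl in place of 4-methoxyphenyl on an aromatic carbon. Among the compounds with values here, the only measured step, a number 6.3 percentage points higher from compound 1 to compound 2 (within the scatter), concerns a group on an aromatic nitrogen and lay within the scatter, so it bears only loosely on a change at an aromatic carbon. Within the data shown here, no measured pair shows 5-methylthiophen-2-yl in place of 4-methoxyphenyl. Compound 4 is therefore expected to move little, with a number 11.6 percentage points lower from compound 3 to compound 4 (beyond the scatter) as a modest downward step at most. The estimate for compound 4 is 66%, within 48% to 84%.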

Compound 4, a percentage reported as inhibition, at one concentration (the size of the read-out at that concentration, not a potency): 79.7%
The estimate for compound 4 lay 13.7 percentage points below the measured number; measured number inside the range.
By their numbers in this assay, from the lowest: compounds 1 and 2 (each within the scatter of the next); then compounds 3 and 4 (each within the scatter of the next).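

In this assay, 5-methylthiophen-2-yl in place of 4-methoxyphenyl on this aromatic carbon gives a number 2.1 percentage points higher from compound 3 to compound 4 (within the scatter). At this position, then, a five-membered aromatic ring with 1 hetero atom and a six-membered aromatic ring of carbon only give numbers that cannot be told apart. No measurement shown offers an explanation for this result.

Still open, on these data alone, is how an amine, a carboxylic acid or a longer alkyl chain on this carbon would read. As far as these compounds go, it is also open whether the step holds with 2-methylphenyl on the aromatic nitrogen.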